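The source may report more compounds than this note shows. Statements on the series, on what has been measured and on what is new or still open speak of the compounds shown alone.

Measured so far, all in an assay on isolated protein for inhibition of Amine oxidase [flavin-containing] B (Homo sapiens), read by fluorescence, with stated times of 15 min and 20 min; a lower number here means a stronger inhibitor, a higher number a weaker inhibitor:

Compound 1, `O=C(CN1CCCCC1)N1N=C(c2ccccc2)CC1c1ccccc1O`, gives 50600 nM.
Compound 2, `O=C(CN1CCCCC1)N1N=C(c2ccc(Cl)cc2)CC1c1ccccc1O`, gives 40100 nM.
Compound 3, `Cc1ccc(C2=NN(C(=O)Cn3ccnc3)C(c3ccccc3O)C2)cc1`, gives 41300 nM.

All three numbers lie close together. Going by the values given here, the only single-point change among the measured compounds is chloro in place of hydrogen on an aromatic carbon, and in this assay that change made a step of a 1.3-fold lower number from compound 1 to compound 2 (0.10 log units; within the scatter), so it barely moved the number. Compound 3 shares the 2-hydroxyphenyl group of compound 1 but differs from it in more than one place; the difference between the two cores is not broken down here.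

Compound 4, `Cc1ccc(C2=NN(C(=O)Cn3ccnc3)C(c3cc(Cl)ccc3O)C2)cc1`, is not yet measured. It differs from compound 3 by chloro in place of hydrogen on an aromatic carbon. Among the compounds with values here, this is the same kind of change as the one from compound 1 to compound 2, but not the same: there the chloro entered para to a large group, whereas here it enters meta to a large group and para to a hydroxy group, on the ring that carries the hydroxy.

Given that the earlier chloro step was a 1.3-fold lower number from compound 1 to compound 2 (0.10 log units; within the scatter), the step from compound 3 to compound 4 is expected to be small as well, about a 1.2-fold lower number from compound 3 to compound 4 (0.07 log units; within the scatter), since nothing among the measured compounds points to a large effect of a single chloro. Compound 4 is therefore estimated to give 35000 nM in this assay, with a likely range from 15000 nM to 80000 nM.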

Compound 4, half-maximal inhibitory concentration: 16100 nM
The estimate for compound 4 lay 2.2-fold (0.34 log units) above the measured number; measured number inside the range.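

In this assay, chloro in place of hydrogen, which turns 2-hydroxyphenyl into 5-chloro-2-hydroxyphenyl, gives a 2.6-fold lower number from compound 3 to compound 4 (0.41 log units; beyond the scatter), so compound 4 is a modestly stronger inhibitor than compound 3. Going by these compounds alone, although only this newer step lies beyond the usual scatter, the two chloro steps cannot be told apart, since the gap between them is no larger than repeated measurements could produce: the same change on two cores in this assay, a 1.3-fold lower number (0.10 log units; within the scatter) from compound 1 to compound 2 and a 2.6-fold lower number (0.41 log units; beyond the scatter) from compound 3 to compound 4, 2.0-fold (0.31 log units) apart, within the scatter of two such steps. Within the data shown here, this fits a chloro effect that carries from one core to the other, but it does not establish one, as it rests on only two steps, and the chloro sits on the ring that carries the hydroxy group in compound 4 but on a different ring in compound 2, so the core and the place of the chloro are mixed together.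

From the compounds shown here alone, it remains open what the 5-chloro-2-hydroxyphenyl group would do on the core of compound 1, a comparison that would separate the effect of the core from that of the place of the chloro. Going by these compounds, it is also open whether bromo, methoxy or a carboxylic acid in that same place would give a number like that of chloro.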